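This account rests on a few compounds, and the source may have more. Where it says the series, first, only, none or still open, it means among the compounds named here.

Compound 2 `Nc1scc(CN2CCN(c3cc(Cl)cc(Cl)c3)CC2)c1C(=O)c1ccc(Cl)cc1` and compound 1 `CC(C)N1CCN(Cc2csc(N)c2C(=O)c2ccc(Cl)cc2)CC1` share a core and differ only on an amine nitrogen in a ring. In an assay on CHO cells for displacement of a labelled ligand from adenosine receptor A1 (Homo sapiens), read by scintillation counting, with a stated time of 120 min, tested at 10 uM (a higher number here means more inhibition at the concentration tested (going by the name of the read-out), a lower number less inhibition), compound 1 gives 0%, and compound 2 gives 1%; the step of a number 1 percentage points higher from compound 1 to compound 2 (within the scatter) lies within the scatter, so compound 2 stands highest of the two numbers without being separable from compound 1. Compound 3 `Nc1scc(CN2CCN(c3ccc(Cl)cc3F)CC2)c1C(=O)c1ccc(Cl)cc1` differs from compound 2 by 4-chloro-2-fluorophenyl in place of 3,5-dichlorophenyl on an amine nitrogen in a ring. For the measured compounds named here, the one comparable step was flat, so compound 3 is expected to give an estimated 2% (range 0% to 12%), a step of a number 1 percentage points higher from compound 2 to compound 3 (within the scatter) not expected to exceed the scatter.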

Compound 3, a percentage reported as inhibition, at one concentration (the size of the read-out at that concentration, not a potency): 0%
Beside the measured number, compound 3's estimate is 2 percentage points above it; low and high end bracket the measured number.
By their numbers in this assay, from the lowest: compounds 1, 3 and 2 (each within the scatter of the next).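

In this assay, the change on the amine nitrogen in a ring gives a number 1 percentage points lower from compound 2 to compound 3 (within the scatter) and no change at the digits printed from compound 1 to compound 3 (within the scatter). The flat result therefore extends to a second substituted phenyl group: 4-chloro-2-fluorophenyl cannot be told apart from either 3,5-dichlorophenyl or isopropyl at this position. No available evidence accounts for this flatness.

The compounds shown leave open whether a benzyl group, a longer chain or a phenyl ring bearing a carboxylic acid on this nitrogen would give any inhibition. They also leave open whether changes elsewhere on the shared core would.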